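Swapping the aryl chloro for hydroxymethyl: notes

A few compounds are considered here, and "the series" means these few. Any claim that something is new, unique, unknown or untested is made for them only; others in the source may bear on it.

Measured so far:
compound 1, `CCN(Cc1cccs1)C(=O)COc1ccc(F)cc1`, gives 422 nM in an assay on HEK293 cells for agonist activity at transient receptor potential cation channel subfamily M member 8 (Homo sapiens), read by fluorescence and calcium flux, with a stated time of 15 min; a higher number here means that more compound is needed for the effect, a lower number that less compound is needed
compound 2, `CCN(Cc1cccs1)C(=O)COc1ccc(Cl)cc1`, gives 39 nM in this assay

Going by the values given here, compound 2 has the lowest number of the two; the only measured step is an 11-fold lower number from compound 1 to compound 2 (1.03 log units; beyond the scatter). Compound 3, `CCN(Cc1cccs1)C(=O)COc1ccc(CO)cc1`, differs from compound 2 by hydroxymethyl in place of chloro on an aromatic carbon. Among the compounds with values here, the one measured step exchanges one halogen for another, whereas compound 3 carries neither, so that step is only a rough guide and the entering group has no measured precedent here. A higher number than for compound 2 is expected, with wide uncertainty. Compound 3 is estimated at 800 nM (range 150 nM to 5000 nM), the expected step being a 21-fold higher number from compound 2 to compound 3 (1.31 log units; beyond the scatter).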

Compound 3, half-maximal effective concentration: 21900 nM
Estimate against measurement, compound 3: 27-fold (1.44 log units) below, outside the stated range (above it).
By their numbers in this assay, from the lowest: compound 2; then compound 1; then compound 3.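

This position responds far more strongly to hydroxymethyl than to the exchange of one halogen for another: the change brings a 560-fold higher number from compound 2 to compound 3 (2.75 log units; beyond the scatter) and a 52-fold higher number from compound 1 to compound 3 (1.72 log units; beyond the scatter). Both steps exceed the fluoro-to-chloro step, and compound 3 has the highest number of the three in this assay. No available data explain this result.

On these data alone, it remains open whether the hydroxyl oxygen or the added carbon drives the step, and methyl or methoxy at this place would separate the two. Bromo would show whether the order between the halogens extends beyond chloro.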